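Carboxy to hydroxymethyl on the ethoxy compound

This account rests on a few compounds, and the source may have more. Where it says the series, first, only, none or still open, it means among the compounds named here.

Measured so far:
compound 1 `CCc1cccc2c(O)c(-c3occ(C)c3C(=O)O)ccc12`; in a functional assay on KBVIN cells (Homo sapiens) for cytotoxicity, read by MTT assay, with a stated time of 72 h (on this read-out higher numbers stand for an effect only at larger amounts of compound and lower numbers for an effect already at smaller amounts), compound 1 gives 7 ug/mL
compound 2 `CCOc1c(-c2occ(C)c2C(=O)O)ccc2c(CC)cccc12`; in this assay compound 2 gives only > 10 ug/mL, which is a limit of the assay and not a number
compound 3 `CCc1cccc2c(OC)c(-c3occ(C)c3C(=S)OC)ccc12`; in this assay compound 3 gives 5.1 ug/mL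

Compound 2 therefore stands at the limit of > 10 ug/mL in this assay, at which 1 of the 3 values shown sits, and its place among the three can only be bounded: the step of an at least 1.4-fold higher number from compound 1 to compound 2 (0.15 log units; that floor lies within the scatter) is a floor that lies within the scatter. Among the measured compounds shown here, compound 3 differs from compound 1 in two places and no single step is counted for it.

Compound 4 `CCOc1c(-c2occ(C)c2CO)ccc2c(CC)cccc12` is the next member, obtained from compound 2 by hydroxymethyl in place of carboxy on an aromatic carbon. For the measured compounds named here, no measured pair shows a carboxy-to-hydroxymethyl exchange, so none of the measured steps bears directly on it, and the starting point is itself only a limit. The expected step that the limit leaves unreadable from compound 2 to compound 4 is thus taken as none beyond the scatter, with wide uncertainty. For compound 4 in this assay the estimate is 12 ug/mL, within 4 ug/mL to 40 ug/mL.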

Compound 4, concentration for half-maximal effect: 6.4 ug/mL
Compound 4: the middle estimate sits 1.9-fold (0.27 log units) above what was measured; the measured number falls inside the stated range.
By their numbers in this assay, from the lowest: compounds 3, 4 and 1 (each within the scatter of the next). At a limit, above all of these: compound 2.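

Among the compounds shown here, the step here (an at least 1.5-fold lower number from compound 2 to compound 4 (0.19 log units; that floor lies within the scatter)) is the first single change at the carboxy position, on an aromatic carbon of the five-membered aromatic ring with 1 oxygen, whereas the earlier step concerned the group on the oxygen. The carboxy group is thus not required for a readable number in this assay (with hydroxymethyl in its place, compound 4 gives 6.4 ug/mL). The full size of this step cannot be read because compound 2 has only a limit: the limit of > 10 ug/mL in this assay, at which 1 of the 4 values shown sits.

Open, on these data alone, is whether hydroxymethyl would give a comparable number alongside the hydroxy group of compound 1. Also open, as far as these compounds go, is whether an amine, a methyl ester or a longer chain on the same carbon would differ from compound 4 beyond the scatter.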